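The source may report more compounds than this note shows. Statements on the series, on what has been measured and on what is new or still open speak of the compounds shown alone.

Of the compounds shown here, three have so far been measured in a physicochemical assay for lipophilicity; a higher number here means a more lipophilic compound, a lower number a more polar compound. Compound 1, `COC(=O)/C=C(C)/C=C/CC(C)CCCC(C)C`, gives 6.2 in this assay. Compound 2, `COC(C)(C)CCCC(C)C/C=C/C(C)=C/C(=O)OC1CCC1`, gives 6.44, a number so close to that of compound 1 that the two lie within the scatter of each other. Compound 3, `CCOC(=O)/C=C(C)/C=C/CC(C)CCC(OC)C(C)(C)OC`, gives 4.34, which stands beyond the scatter below compound 1. On these numbers compound 1 therefore sits with compound 2 at the upper end and clearly above compound 3.

Compound 4, `CC(/C=C/CC(C)CCCC(C)C)=C\C(=O)N(C)C`, has not yet been measured. It differs from compound 1 in one place: dimethylamino in place of methoxy on a carbonyl carbon. Within the data shown here, no pair of measured compounds covers this change, so its size in this assay cannot be read off and can only be expected. The expectation is a downward step, beyond the scatter, of a number 1.30 log units lower from compound 1 to compound 4 (beyond the scatter). On that basis compound 4 is estimated at 4.9 in this assay, with a range from 4.2 to 5.6.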

Compound 4, partition coefficient: 4.94
For compound 4 the middle estimate is 0.04 log units below the measured one; low and high end bracket the measured number.
By their numbers in this assay, from the lowest: compound 3; then compound 4; then compounds 1 and 2 (each within the scatter of the next).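

With this result, the position on a carbonyl carbon has its first measured step between compounds that differ in one place: in this assay, dimethylamino in place of methoxy gives a number 1.26 log units lower from compound 1 to compound 4 (beyond the scatter). The step shows that this position is not indifferent to the group it carries, and that a change there can move the number well beyond the scatter, even though the entering dimethylamino has 3 heavy atoms against 2 for the leaving methoxy. Nothing shown here accounts for the size or direction of this step.

The compounds shown leave open where a carboxylic acid, methylamino or a pyrrolidine amide at the same carbonyl carbon would stand. They also leave open whether the same change would give a step of similar size on the core of compound 3, with its two methoxy groups.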